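The source may hold more compounds than are shown below. What is called first, only, known or untested is meant among the compounds shown, and "the series" means these compounds.

The measured compounds:
compound 1 `COc1ccc(F)cc1CNCCCNc1ccnc2cc(Cc3ccc(F)cc3Cl)ccc12`: in an ADME assay on HepG2 cells (Homo sapiens) for cytotoxicity, read by luminescence, CellTiter-Glo and ATP content, with a stated time of 72 h (a higher number here means that more compound is needed for the effect, a lower number that less compound is needed), compound 1 gives 2460 nM
compound 2 `Fc1ccc(Cc2ccc3c(NCCCNCc4ccco4)ccnc3c2)c(Cl)c1`: in this assay compound 2 gives 5730 nM

Compound 1 stands lowest of these two numbers. Its nearest neighbour is compound 2, reached by a 2.3-fold higher number from compound 1 to compound 2 (0.37 log units; beyond the scatter), a modest step that lies beyond the usual scatter; that step puts furan-2-yl in place of 5-fluoro-2-methoxyphenyl on a saturated chain carbon bound to an amine nitrogen.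

Compound 3 `COc1ccc(F)cc1CNCCCNc1ccnc2cc(Cc3cc(C)cc(C)c3)ccc12` has not been measured. It differs from compound 1 at a different site of the shared core: 3,5-dimethylphenyl in place of 2-chloro-4-fluorophenyl on a saturated chain carbon bound to an aromatic carbon. For the measured compounds named here, the one measured step, that from compound 1 to compound 2, alters the amine-side group and leaves this ring untouched, so no measured step bears on the present change. Both the departing and the arriving groups are single six-membered aromatic rings of carbon only, with no donors or acceptors. With nothing to point either way, the expected step in this assay is none beyond the scatter, and the estimate is accordingly broad.

Compound 3 is therefore expected to give about 2500 nM, within 1000 nM to 6500 nM. The expected step, a 1.0-fold higher number from compound 1 to compound 3 (0.01 log units; within the scatter), is estimated to remain within the scatter.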

Compound 3, half-maximal effective concentration: 940 nM
Compound 3: middle estimate off by 2.7-fold (0.42 log units), on the high side; measured number outside the range, below it.
By their numbers in this assay, from the lowest: compound 3; then compound 1; then compound 2.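

The change swaps 2-chloro-4-fluorobenzyl for 3,5-dimethylbenzyl and leaves the amine side and the shared core as they are, and it gives a 2.6-fold lower number from compound 1 to compound 3 (0.42 log units; beyond the scatter) in this assay, so less compound is needed for the effect. This shows that the place on a saturated chain carbon bound to an aromatic carbon also affects the number, as the amine side already did, and that the direction here is opposite to the earlier 2.3-fold higher number from compound 1 to compound 2 (0.37 log units; beyond the scatter). The two groups have the same count of heavy atoms, each has one six-membered aromatic ring of carbon only, and neither has hydrogen-bond donors or acceptors, so these shared counts do not fix the number, and no measurement at hand explains the shift.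

Because the chlorine and fluorine leave and the two methyl groups enter in a single step, the compounds shown cannot separate the contribution of each, a question that an unsubstituted phenyl ring, a 3,5-dichlorophenyl ring or a 2,4-dimethylphenyl ring at this place could address. They also leave open whether 3,5-dimethylphenyl would lower the number to a similar extent with furan-2-yl on the amine side.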